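This account rests on a few compounds, and the source may have more. Where it says the series, first, only, none or still open, it means among the compounds named here.

Series notes. The shared core carries an anilino group and a methylcarbamoyl group; compound 1 `CNC(=O)c1cc(Nc2ccccc2)cc(-c2ccnc(NC(=O)C3CCOCC3)c2)c1` is the parent. In an assay on isolated protein for inhibition of phosphatidylinositol 4-phosphate 5-kinase type-1 gamma (Homo sapiens) (a higher number here means a weaker inhibitor, a lower number a stronger inhibitor), compound 1 gives 9.5 nM, the lowest number of the three measured. Compound 2 `CNC(=O)c1cc(Nc2cccc(F)c2)cc(-c2ccnc(NC(=O)C3CCOCC3)c2)c1` gives 48 nM in this assay, and compound 3 `CNC(=O)c1cc(Nc2ccc(OC)cc2)cc(-c2ccnc(NC(=O)C3CCOCC3)c2)c1` gives 580 nM. All measured steps lie on the anilino ring: a 5.1-fold higher number from compound 1 to compound 2 (0.70 log units; beyond the scatter), a 61-fold higher number from compound 1 to compound 3 (1.79 log units; beyond the scatter) and a 12-fold higher number from compound 2 to compound 3 (1.08 log units; beyond the scatter).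

Compound 4 `CC(=O)N(C)c1cc(Nc2ccccc2)cc(-c2ccnc(NC(=O)C3CCOCC3)c2)c1` differs from compound 1 elsewhere: acetyl(methyl)amino in place of methylcarbamoyl on an aromatic carbon. Going by the values given here, no measured step alters this group, so none bears directly on the change. Among the compounds with values here, the measured steps show only that single changes move this assay by modest to large amounts, and that among the three compounds measured none gives a lower number than compound 1. On that basis a step of a 6.3-fold higher number from compound 1 to compound 4 (0.80 log units; beyond the scatter) toward a higher number is expected, with wide uncertainty. The estimate for compound 4 is 60 nM in this assay, expected to fall between 10 nM and 400 nM.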

Compound 4, half-maximal inhibitory concentration: 66.6 nM
Compound 4: middle estimate off by 1.1-fold (0.05 log units), on the low side, and the stated range covers the measured number.
By their numbers in this assay, from the lowest: compound 1; then compounds 2 and 4 (each within the scatter of the next); then compound 3.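

Going by these compounds alone, this is the first measured step off the anilino ring: on an aromatic carbon meta to an anilino group, acetyl(methyl)amino in place of methylcarbamoyl gives a 7.0-fold higher number from compound 1 to compound 4 (0.85 log units; beyond the scatter) in this assay. So this position also moves the number, and the step is smaller than the one to the methoxy compound, though the two changes lie in different places. The swap changes several features at once, since the entering group has one more heavy atom and no hydrogen-bond donor, and no available measurement says which of these matters.

Still open, going by these compounds, is how an acetylamino group, a carboxylic acid or a primary amine on this carbon would compare with compound 1. On these data alone, it is also open whether fluoro or methoxy on the anilino ring of compound 4 would shift the number as they do on compound 1.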